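The source may hold more compounds than are shown below. What is called first, only, known or untested is meant among the compounds shown, and "the series" means these compounds.

Compound 2 `COc1ccc(CN(Cc2ccc(C(C)(C)C)cc2)Cc2cc3cc(C)ccc3[nH]c2=O)cc1` stands only at a limit of the assay: in a toxicity assay on MDCK cells (Canis lupus familiaris) for cytotoxicity, read by crystal violet staining, with a stated time of 48 h (a lower number here means that less compound is tolerated, a higher number that more compound is tolerated), compound 2 gives > 10000 nM, a limit and not a number. Among the compounds with values here, compound 1 `Cc1ccc2[nH]c(=O)c(CN(Cc3ccc(OCC(=O)O)cc3)Cc3ccc(C(C)(C)C)cc3)cc2c1` is the one other compound with a value here, and it too sits at a limit, since in this assay compound 1 gives > 10000 nM. The step from compound 1 to compound 2 is therefore a step that the two limits leave unreadable from compound 1 to compound 2, and it cannot be read in either direction, as the limit of > 10000 nM in this assay, at which 2 of the 2 values shown sit, shows.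

Compound 3 `CCCOc1ccc(CN(Cc2ccc(C(C)(C)C)cc2)Cc2cc3cc(C)ccc3[nH]c2=O)cc1` differs from compound 2 by ethyl in place of hydrogen on a saturated chain carbon bound to an oxygen on an aromatic ring. Within the data shown here, no measured step bears readably on this change: the one step that is known, the one from compound 1 to compound 2, is hidden by the two limits, and neither compound 1 nor compound 2 gives a number to anchor a direction. What the two values do show is that both compounds are tolerated up to the limit of the assay. On that basis the step that the limit leaves unreadable from compound 2 to compound 3 is expected to be none beyond the scatter, with the chance of a readable number small. For compound 3 the estimated value in this assay is 20000 nM, within a range from 7000 nM to 60000 nM.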

Compound 3, half-maximal cytotoxic concentration: > 5000 nM
Compound 3 ended at the assay's limit; the forecaster's own chance of this, stated with the estimate: 80%; the middle value is on the limit's open side.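

In this assay compound 3 gives > 5000 nM, a limit and not a number. Compound 1, compound 2 and compound 3 all stand at limits, so neither step to compound 3 can be read. The compounds shown leave open where the half-maximal cytotoxic concentration of each actually lies, and whether any of these changes moves it at all.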